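Adding a Carboxymethyl Arm to Compound 1

The source may hold more compounds than are shown below. What is called first, only, known or untested is meant among the compounds shown, and "the series" means these compounds.

Of the compounds shown here, two have been measured in an assay on NK92 cells for inhibition of interleukin-2 (Homo sapiens), read by AlphaScreen, with stated times of 30 min and 1 h; on this read-out higher numbers stand for weaker inhibition and lower numbers for stronger inhibition. Compound 1 `Cn1c(Cc2nn(C)c(=O)c3ccccc23)nnc1SCC(=O)Nc1ccc(Cl)cc1Cl` stands at the high end with 7700 nM. Compound 2 `Cn1nc(Cc2nnc(SCCCCCCCC(=O)Nc3ccc(Cl)cc3Cl)[nH]2)c2ccccc2c1=O`, which carries a far longer linker between the sulfur and the amide, gives 450 nM, and the gap between the two lies well beyond the usual scatter, so compound 2 is the stronger inhibitor of the pair.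

Compound 3 `Cn1nc(Cc2nnc(SCC(=O)Nc3ccc(Cl)cc3Cl)n2CCC(=O)O)c2ccccc2c1=O` has not yet been tested in this assay. It differs from compound 1 in one place: carboxymethyl in place of hydrogen on a saturated chain carbon bound to an aromatic nitrogen. Among the compounds with values here, no measured pair in the set shows this kind of change, so there is no direct precedent for its effect. The step from compound 1 to compound 3 is therefore expected to be small, a 1.3-fold lower number from compound 1 to compound 3 (0.11 log units; within the scatter), and might well fall within the scatter in either direction. On that basis compound 3 is estimated to give about 6000 nM, with a plausible range from 1500 nM to 25000 nM.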

Compound 3, half-maximal inhibitory concentration: > 30000 nM
Compound 3: no number, only a limit; the forecaster's own chance of this, stated with the estimate: 15%; middle value at least 5.0-fold (0.69 log units) from the limit.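

The value of compound 3 is a limit of the assay and not a number: the limit of > 30000 nM in this assay, at which 1 of the 3 values shown sits. Even so, the direction of the change can be read: carboxymethyl in place of hydrogen on a saturated chain carbon bound to an aromatic nitrogen, which can also be read as methyl to 2-carboxyethyl, gives an at least 3.8-fold higher number from compound 1 to compound 3 (0.59 log units; beyond the scatter). The earlier compounds shown here said nothing about this position, and this step shows that what sits there matters, since the change weakens inhibition rather than leaving it unchanged.

Going by these compounds, what remains open is whether the carboxylic acid or the longer chain accounts for this loss; a plain propyl chain, a methyl ester or an amine at the same place would help to separate the two. On these data alone, whether the same change would cost as much alongside the longer linker of compound 2 also remains open.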